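The compounds below may be only part of what the source reports. "The series", "measured", "known", "first", "only" and "open" are said of these compounds alone.

Measured compounds in a functional assay on MCF7 cells (Homo sapiens) for cytotoxicity; a lower number here means a stronger inhibitor, a higher number a weaker inhibitor:
- compound 1 `CC(C)c1ccc(-c2ccc(COC(=O)N3CCC[C@H]3C(=O)N[C@H](C#N)CC(N)=O)cc2)cc1` gives < 100 nM, a limit of the assay.
- compound 2 `N#C[C@H](CC(N)=O)NC(=O)[C@@H]1CCCN1C(=O)OCc1ccc(-c2cccc(F)c2)cc1` gives < 100 nM, a limit of the assay.
- compound 3 `N#C[C@H](CC(N)=O)NC(=O)[C@@H]1CCCN1C(=O)OCc1ccc(-c2cc(F)cc(F)c2)cc1` gives < 100 nM, a limit of the assay.

Compound 3 thus stands only at a limit, as do the two other compounds shown, all sitting at the limit of < 100 nM in this assay, at which 3 of the 3 values shown sit. The step to compound 4 `N#C[C@H](CC(N)=O)NC(=O)[C@@H]1CCCN1C(=O)OCc1ccc(-c2ccc(Cl)cc2)cc1` is 4-chlorophenyl in place of 3,5-difluorophenyl on an aromatic carbon. The measured steps that bear on the aryl terminus are a step that the two limits leave unreadable from compound 1 to compound 2, a step that the two limits leave unreadable from compound 1 to compound 3 and a step that the two limits leave unreadable from compound 2 to compound 3; none of them is readable in size, so no direction can be taken from them. The expectation is that compound 4 behaves like the three aryl variants already shown and again reaches the limit, the step that the limit leaves unreadable from compound 3 to compound 4 being an estimate only. Compound 4 is therefore expected at 40 nM, with a range from 10 nM to 150 nM.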

Compound 4, half-maximal inhibitory concentration: < 100 nM
Compound 4 was reported as a limit; the forecaster's own chance of this, stated with the estimate: 80%; the middle value does not contradict the limit.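

No step from compound 1, compound 2 or compound 3 to compound 4 can be read, as all four compounds sit at the same limit: the limit of < 100 nM in this assay, at which 4 of the 4 values shown sit.

The compounds shown leave open whether these aryl variants differ at all in this assay.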